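Hydroxy for methoxy on a pyrazole antiproliferative series

This account rests on a few compounds, and the source may have more. Where it says the series, first, only, none or still open, it means among the compounds named here.

Three compounds have been measured in a functional assay on SK-MEL-2 cells (Homo sapiens) for antiproliferative activity, read by sulforhodamine B assay, with a stated time of 48 h; a lower number here means a stronger inhibitor, a higher number a weaker inhibitor:

compound 1, `COc1cc(-c2nn(-c3ccc(NC(=O)Nc4ccc(Cl)c(Cl)c4)cc3)cc2-c2ccncc2)ccc1Cl`, 3440 nM
compound 2, `COc1cc(-c2nn(-c3ccc(NC(=O)c4ccc(Cl)c(C(F)(F)F)c4)cc3)cc2-c2ccncc2)ccc1Cl`, 3150 nM
compound 3, `O=C(Nc1ccc(-n2cc(-c3ccncc3)c(-c3ccc(Cl)c(O)c3)n2)cc1)Nc1cc(C(F)(F)F)cc(C(F)(F)F)c1`, 1800 nM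

Compound 2 gives the second highest of the three numbers, but its gap to compound 1 and its gap to compound 3 both lie within the scatter, so the three are not separated. The one listed step, a 1.1-fold lower number from compound 1 to compound 2 (0.04 log units; within the scatter), exchanged the urea for an amide and moved nothing.

Compound 4, `O=C(Nc1ccc(-n2cc(-c3ccncc3)c(-c3ccc(Cl)c(O)c3)n2)cc1)c1ccc(Cl)c(C(F)(F)F)c1`, keeps the amide of compound 2 and carries hydrogen in place of methyl on an oxygen on an aromatic ring. Among the measured compounds shown here, no measured step tests this change alone: compound 3 has the hydroxy group but also a different amide partner, so its value and that of compound 2 can only be compared as they stand, and they are within the scatter of each other. On that basis compound 4 is expected to stay near compound 2, with a step of a 1.3-fold lower number from compound 2 to compound 4 (0.10 log units; within the scatter), so its number in this assay is estimated at 2500 nM, in a range from 1000 nM to 7000 nM.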

Compound 4, half-maximal inhibitory concentration: 1580 nM
Beside the measured number, compound 4's estimate is 1.6-fold (0.20 log units) above it; the range from low to high includes it.
By their numbers in this assay, from the lowest: compounds 4, 3, 2 and 1 (each within the scatter of the next, the first and the last beyond it).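

Among the compounds shown here, with the amide held fixed, hydrogen in place of methyl on an oxygen on an aromatic ring gives a 2.0-fold lower number from compound 2 to compound 4 (0.30 log units; within the scatter) in this assay, the first reading of methoxy to hydroxy as a single change. The earlier compounds shown here could not give this reading, since compound 3 carries the hydroxy group together with a different partner on the carbonyl. On this amide, then, 4-chloro-3-hydroxyphenyl and 4-chloro-3-methoxyphenyl are not separated in this assay, and no evidence is available that bears on this result.

The compounds shown leave open whether the same change on a urea such as compound 1 would give a similar step. They also leave open how an amine or an ethoxy group in place of the hydroxy group would read in this assay.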